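Compound 3: 2-phenylethenyl in place of phenoxymethyl

This account rests on a few compounds, and the source may have more. Where it says the series, first, only, none or still open, it means among the compounds named here.

In a toxicity assay on KB cells (Homo sapiens) for cytotoxicity, read by fluorescence, with a stated time of 3 days (on this read-out higher numbers stand for an effect only at larger amounts of compound and lower numbers for an effect already at smaller amounts), compound 1 (`CCCCOC(=O)CNC(=O)[C@H](CSc1ccc([N+](=O)[O-])cc1[N+](=O)[O-])NC(=O)CC[C@H](NC(=O)CC(C)C)C(=O)OCCCC`) gives 59.6 uM. Compound 2 (`CCCCOC(=O)CNC(=O)[C@H](CSc1ccc([N+](=O)[O-])cc1[N+](=O)[O-])NC(=O)CC[C@H](NC(=O)COc1ccccc1)C(=O)OCCCC`) gives > 300 uM, which is a limit of the assay and not a number. Compound 2 therefore stands at the limit of > 300 uM in this assay, at which 1 of the 2 values shown sits.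

Compound 3 (`CCCCOC(=O)CNC(=O)[C@H](CSc1ccc([N+](=O)[O-])cc1[N+](=O)[O-])NC(=O)CC[C@H](NC(=O)/C=C/c1ccccc1)C(=O)OCCCC`) carries 2-phenylethenyl in place of phenoxymethyl on a carbonyl carbon.

Within the data shown here, one measured step bears on this change, at the same acyl group: an at least 5.0-fold higher number from compound 1 to compound 2 (0.70 log units; beyond the scatter), which is beyond the scatter, with phenoxy in place of isopropyl. Compound 3 gives up that phenoxy but keeps an aromatic ring, so only a partial return towards compound 1 is expected. A modest move to lower numbers in this assay is expected, although the start is only a limit. The estimated step is an at least 2.5-fold lower number from compound 2 to compound 3 (0.39 log units; beyond the scatter). Compound 3 is estimated at 120 uM, with an expected range of 40 uM to 300 uM.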

Compound 3, concentration for half-maximal effect: 34.4 uM
Compound 3: the middle estimate sits 3.5-fold (0.54 log units) above what was measured; the whole stated range lies above it.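

In this assay, an aromatic ring on this carbonyl carbon does not by itself go with the high number of compound 2: with phenoxymethyl leaving and 2-phenylethenyl entering, and one six-membered aromatic ring on both sides, the result is an at least 8.7-fold lower number from compound 2 to compound 3 (0.94 log units; beyond the scatter). Isobutyl and 2-phenylethenyl at this place are not told apart in this series, with a 1.7-fold lower number from compound 1 to compound 3 (0.24 log units; within the scatter), so an aromatic and an aliphatic group can both sit here with no separation beyond the scatter. The size of the first step remains open-ended, as compound 2 is a limit of the assay and not a number: the limit of > 300 uM in this assay, at which 1 of the 3 values shown sits.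

The compounds shown leave open whether the oxygen of phenoxymethyl or the double bond of 2-phenylethenyl decides the step, as the two change together. A 2-phenylethyl group on the same carbonyl carbon would separate them.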